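Phenyl to pyridin-3-yl on the more active compound

The compounds below may be only part of what the source reports. "The series", "measured", "known", "first", "only" and "open" are said of these compounds alone.

For the measured compounds named here, in a functional assay on a cell-free system (plasma, Homo sapiens) for inhibition, with Plasma (Rattus norvegicus) as the target (on this read-out higher numbers stand for weaker inhibition and lower numbers for stronger inhibition), compound 2 `Cc1c(OCc2ccccc2)ccc2c(N3CCNCC3)cc(=O)oc12` gives 1100 nM, the lowest of the two numbers so far, while compound 1 `O=c1cc(N2CCNCC2)c2ccc(OCc3ccccc3)cc2o1` gives 78800 nM. Going by the values given here, the only measured step, a 72-fold lower number from compound 1 to compound 2 (1.86 log units; beyond the scatter), came from methyl in place of hydrogen on an aromatic carbon. Compound 3 `Cc1c(OCc2cccnc2)ccc2c(N3CCNCC3)cc(=O)oc12` keeps that methyl and differs elsewhere: pyridin-3-yl in place of phenyl on a saturated chain carbon bound to an oxygen on an aromatic ring. Among the compounds with values here, no measured step covers this swap, so the large methyl step sets no size for it. A modest move towards a higher number is expected, an estimated 2.3-fold higher number from compound 2 to compound 3 (0.36 log units; beyond the scatter). Compound 3 is estimated at 2500 nM, with an expected range of 600 nM to 10000 nM.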

Compound 3, half-maximal inhibitory concentration: 1420 nM
The estimate for compound 3 lay 1.8-fold (0.25 log units) above the measured number; the range from low to high includes it.
By their numbers in this assay, from the lowest: compounds 2 and 3 (each within the scatter of the next); then compound 1.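

In this assay, pyridin-3-yl in place of phenyl gives a 1.3-fold higher number from compound 2 to compound 3 (0.11 log units; within the scatter), so the two numbers cannot be told apart. With the methyl kept, this place on a saturated chain carbon bound to an oxygen on an aromatic ring therefore takes a ring nitrogen with no measurable loss of inhibition. Nothing available explains this result.

On these data alone, whether pyridin-4-yl, or a phenyl ring carrying an amine or a carboxylic acid, would also hold the number remains open. So does whether pyridin-3-yl behaves the same way without the methyl.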